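Swapping Methyl for Fluoro on the Shared Core

The source may hold more compounds than are shown below. What is called first, only, known or untested is meant among the compounds shown, and "the series" means these compounds.

Measured compounds:
- compound 1, `Cc1cc(C)c(-c2ncc[nH]2)cc1NC(=O)c1ccc(OCc2ccccn2)cc1`, 18 uL/min
- compound 2, `Cc1ncc(-c2cc(NC(=O)c3ccc(OCc4ccccn4)cc3)c(C)cc2C)[nH]1`, 32 uL/min

Among the compounds with values here, in an ADME assay on cells (Hepatocyte, Rattus norvegicus) for metabolic stability (on this read-out higher numbers stand for fast clearance and lower numbers for slow clearance), compound 1 gives 18 uL/min, the lowest of the two numbers so far. Compound 2 gives 32 uL/min, and the step of a 1.8-fold higher number from compound 1 to compound 2 (0.25 log units; within the scatter) lies within the usual scatter, so the two compounds cannot be told apart on this read-out.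

Compound 3, `Cc1cc(F)c(-c2ncc[nH]2)cc1NC(=O)c1ccc(OCc2ccccn2)cc1`, is the next compound. It differs from compound 1 by fluoro in place of methyl on an aromatic carbon. Within the data shown here, the single measured step concerns a different group at a different place on the core, so no measured step bears directly on this change. With nothing pointing in either direction, the change is expected to give a 1.1-fold lower number from compound 1 to compound 3 (0.02 log units; within the scatter), that is, no step beyond the scatter. Compound 3 is therefore estimated at 17 uL/min, with a range from 8 uL/min to 34 uL/min.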

Compound 3, intrinsic clearance in a liver preparation (reported as CLH), per the amount of preparation that the assay uses: 14 uL/min
For compound 3 the middle estimate is 1.2-fold (0.08 log units) above the measured one, and the stated range covers the measured number.
By their numbers in this assay, from the lowest: compounds 3, 1 and 2 (each within the scatter of the next, the first and the last beyond it).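

On the aromatic carbon ortho to the 1H-imidazol-2-yl group and para to a large group, fluoro in place of methyl gives a 1.3-fold lower number from compound 1 to compound 3 (0.11 log units; within the scatter) in this assay. Within the data shown here, this is the first measured change at this position, since the earlier step concerned a different group at a different place on the core. On this read-out, the position takes either methyl or fluoro with no step beyond the scatter, and no measurement at hand explains this result.

From the compounds shown here alone, with only these two small groups seen here, it remains open how a chloro, a methoxy or an amine at this position would read. Going by these compounds, it is also open whether fluoro would read the same alongside the 2-methyl-1H-imidazol-5-yl group of compound 2.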